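The source may hold more compounds than are shown below. What is called first, only, known or untested is meant among the compounds shown, and "the series" means these compounds.

Compound 1 `Clc1ccc(CO/N=C/c2c(-c3ccc4ccccc4c3)nc3sccn23)cc1Cl`: 380 nM
Compound 2 `Clc1ccc(-c2nc3occn3c2/C=N/OCc2ccc(Cl)c(Cl)c2)cc1`: 410 nM
Compound 3 `C(=N/OC1Cc2ccccc2C1)\c1c(-c2ccc3ccccc3c2)nc2occn12`: 980 nM

The three compounds above were tested in an assay on HepG2 cells for agonist activity at nuclear receptor subfamily 1 group I member 3 (Homo sapiens), read by a luciferase reporter, with a stated time of 23 h; on this read-out lower numbers stand for an effect already at smaller amounts and higher numbers for an effect only at larger amounts of compound. Compound 1 has the lowest number of the three. Its nearest neighbour is compound 2, whose value lies within the scatter of repeated measurements, so the two cannot be told apart. Compound 3 is the furthest away, and its gap to compound 1 lies beyond the scatter.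

The next compound, compound 4 `Clc1ccc(CO/N=C/c2c(-c3ccccc3)nc3sccn23)cc1Cl`, has not yet been measured in this assay. It differs from compound 1 in one place: phenyl in place of naphthalen-2-yl on an aromatic carbon. The group that leaves has two six-membered aromatic rings of carbon only; the group that enters has one. Among the measured compounds shown here, no measured pair in this set shows the effect of exactly this change, so the step cannot be read off from the data and must be estimated.

The expectation is that compound 4 shows a moderate step toward a higher number, that is, toward an effect only at larger amounts, as given by a 3.2-fold higher number from compound 1 to compound 4 (0.50 log units; beyond the scatter). The estimated value for compound 4 is 1200 nM, within a range from 400 nM to 4000 nM.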

Compound 4, half-maximal effective concentration: 580 nM
The estimate for compound 4 lay 2.1-fold (0.32 log units) above the measured number; measured number inside the range.
By their numbers in this assay, from the lowest: compounds 1, 2, 4 and 3 (each within the scatter of the next, the first and the last beyond it).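

In this assay, replacing naphthalen-2-yl with phenyl on this aromatic carbon gives a 1.5-fold higher number from compound 1 to compound 4 (0.18 log units; within the scatter), so the two compounds cannot be told apart. The earlier compounds shown here offered no pair that isolated this position; this pair shows that, on the core of compound 1, removing one of the two six-membered aromatic rings leaves the number within the scatter. No measurement here gives a reason for this result.

From the compounds shown here alone, what happens with a group other than an all-carbon aromatic ring at this place stays open, for example a methyl group, an amine or a morpholine ring. Going by these compounds, it is also open whether phenyl in place of naphthalen-2-yl would give a similarly small step in a compound built like compound 3.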